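A few compounds are considered here, and "the series" means these few. Any claim that something is new, unique, unknown or untested is made for them only; others in the source may bear on it.

Working notes on the series sharing the core of compound 1 (`c1ccc(-c2ccc(-c3ccc(-c4nc5ccccc5[nH]4)cc3)cc2)cc1`). In a functional assay on ZR-75-1 cells (Homo sapiens) for inhibition, read by sulforhodamine B assay (on this read-out higher numbers stand for weaker inhibition of growth and lower numbers for stronger inhibition of growth), compound 1 gives 100000 nM and compound 2 (`Fc1ccc(-c2ccc(-c3ccc(-c4nc5ccccc5[nH]4)cc3)cc2)cc1`) gives 100000 nM. Fluoro in place of hydrogen shows no change at the digits printed from compound 1 to compound 2 (within the scatter). Compound 3 (`FC(F)(F)c1ccc(-c2ccc(-c3ccc(-c4nc5ccccc5[nH]4)cc3)cc2)cc1`) gives 48300 nM, the lowest of the three numbers, with a 2.1-fold lower number from compound 1 to compound 3 (0.32 log units; beyond the scatter) and a 2.1-fold lower number from compound 2 to compound 3 (0.32 log units; beyond the scatter). Compound 4 (`Oc1ccc(-c2ccc(-c3ccc(-c4nc5ccccc5[nH]4)cc3)cc2)cc1`) follows from compound 3 by hydroxy in place of trifluoromethyl on an aromatic carbon. For the measured compounds named here, no measured step involves hydroxy, and the only steps beyond the scatter so far are these two modest ones, so the guidance is weak. No step beyond the scatter is expected, the estimate being a 1.0-fold higher number from compound 3 to compound 4 (0.02 log units; within the scatter). For compound 4 the estimated value in this assay is 50000 nM, with an expected range of 8000 nM to 100000 nM.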

Compound 4, concentration for 50% growth inhibition: 100000 nM
Compound 4: middle estimate off by 2.0-fold (0.30 log units), on the low side; the range from low to high includes it.
By their numbers in this assay, from the lowest: compound 3; then compounds 1, 2 and 4 (each within the scatter of the next).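

In this assay, on an aromatic carbon para to a large group, hydroxy does not hold the lower number seen with trifluoromethyl (a 2.1-fold higher number from compound 3 to compound 4 (0.32 log units; beyond the scatter)). Hydroxy instead reads level with hydrogen (no change at the digits printed from compound 1 to compound 4 (within the scatter)) and with fluoro (no change at the digits printed from compound 2 to compound 4 (within the scatter)), so the lower number stays with trifluoromethyl alone among the four groups at this position. Nothing available here accounts for this difference.

From the compounds shown here alone, whether an amine, a carboxylic acid or a longer chain at this position would side with trifluoromethyl or with the other three groups stays open.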